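The source may hold more compounds than are shown below. What is called first, only, known or untested is meant among the compounds shown, and "the series" means these compounds.

Compound 2 `Cc1ccn2cc(-c3ccc([N+](=O)[O-])cc3)nc2c1` and compound 1 `COc1cc(OC)n2cc(-c3ccc([N+](=O)[O-])cc3)nc2n1` share one core and carry the same nitro-bearing ring. In a functional assay on A549 cells (Homo sapiens) for antiproliferative activity, read by MTT assay, with a stated time of 72 h (a lower number here means a stronger inhibitor of growth, a higher number a weaker inhibitor of growth), compound 1 gives 36600 nM, and compound 2 gives 62400 nM. Compound 2 has the higher of these two numbers, but its nearest neighbour, compound 1, lies within the scatter of it, so the two cannot be told apart. Compound 3 `Cc1ccn2cc(-c3ccc(N)cc3)nc2c1` is built from compound 2 by one change: amino in place of nitro on an aromatic carbon. Within the data shown here, no measured pair here shows what this change does in this assay, so nothing known about the series points in either direction. The expectation is therefore a step of a 1.0-fold lower number from compound 2 to compound 3 (0.02 log units; within the scatter) that stays within the scatter. Compound 3 is estimated at 60000 nM in this assay, with a plausible range from 20000 nM to 200000 nM.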

Compound 3, concentration for 50% growth inhibition: > 100000 nM
Compound 3 ended at the assay's limit; the forecaster's own chance of this, stated with the estimate: 25%; at least 1.6-fold (0.22 log units) between middle value and limit.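

In this assay compound 3 gives > 100000 nM, which is a limit of the assay and not a number. Amino in place of nitro on an aromatic carbon, para to a large group, gives an at least 1.6-fold higher number from compound 2 to compound 3 (0.20 log units; that floor lies within the scatter); this is the first reading of any change at this position, and it shows no sign that amino brings stronger growth inhibition than nitro. How large the step really is cannot be told, because the reading stops at the limit: the limit of > 100000 nM in this assay, at which 1 of the 3 values shown sits.

As far as these compounds go, whether another group at this position, such as a carboxylic acid or a nitrile, would give a lower number than nitro stays open. So does whether amino in place of nitro would act the same way on the core of compound 1.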